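Replacing the isopropyl arm with methoxymethyl on compound 2

The source may hold more compounds than are shown below. What is called first, only, known or untested is meant among the compounds shown, and "the series" means these compounds.

Of the compounds shown here, two of one series have been measured so far. Compound 1 `CCCNc1nnc(SCC(=O)N(Cc2cccc([N+](=O)[O-])c2)c2ccc(F)cc2)s1` gives 45.2% in an assay on isolated protein for inhibition of Amine oxidase [flavin-containing] A (Homo sapiens), read by fluorescence and Amplex Red, with a stated time of 30 min, tested at 0.1 uM; on this read-out higher numbers stand for a stronger effect at the one concentration tested and lower numbers for a weaker effect. Going by the values given here, compound 2 `CC(C)CNc1nnc(SCC(=O)N(Cc2cccc([N+](=O)[O-])c2)c2ccc(F)cc2)s1` gives 31.8% in this assay, the lower of the two numbers, and the single step between them, a number 13.4 percentage points lower from compound 1 to compound 2 (beyond the scatter), lies beyond the scatter, so compound 2 stands as the weaker of the pair.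

Compound 3 `COCCNc1nnc(SCC(=O)N(Cc2cccc([N+](=O)[O-])c2)c2ccc(F)cc2)s1` has not yet been measured in this assay. It differs from compound 2 in one place: methoxymethyl in place of isopropyl on a saturated chain carbon bound to a nitrogen on an aromatic ring.

Among the compounds with values here, the only step on record, a number 13.4 percentage points lower from compound 1 to compound 2 (beyond the scatter), concerns the same saturated chain but a different alteration, so it bears on the new change only loosely. It shows that adding a branch point on that chain cost a modest amount; compound 3 removes that branch and carries an unbranched chain again, as compound 1 does. Compound 3 is therefore expected to recover part of what compound 2 lost, with a step of a number 8.2 percentage points higher from compound 2 to compound 3 (within the scatter) expected, upward but small. Compound 3 is estimated at 40%, within 22% to 58%.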

Compound 3, a percentage reported as inhibition, at one concentration (the size of the read-out at that concentration, not a potency): 61.1%
Compound 3: the middle estimate sits 21.1 percentage points below what was measured; measured number outside the range, above it.
By their numbers in this assay, from the lowest: compound 2; then compound 1; then compound 3.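

In this assay, exchanging isopropyl for methoxymethyl, with the same count of heavy atoms, gives a number 29.3 percentage points higher from compound 2 to compound 3 (beyond the scatter). The earlier pair showed only that a methyl branch on this chain went with a lower number, but the return to an unbranched chain does not describe the whole result: with no branch on either side, methoxy in place of methyl gives a number 15.9 percentage points higher from compound 1 to compound 3 (beyond the scatter), which places compound 3 above both other compounds and shows that this position can respond to a change in the chain other than branching. Nothing available explains why the methoxy-bearing chain gives the higher number.

The three compounds leave open whether the gain depends on the methoxy group itself, a question that a hydroxyl or a dimethylamino group at the end of the chain, or a longer chain such as 3-methoxypropyl, would address. Each number also comes from a single concentration, so the compounds can be described only as showing a stronger or weaker effect at that concentration.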